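Removing One Methyl from a Dimethylpiperazine Antagonist

The source may report more compounds than this note shows. Statements on the series, on what has been measured and on what is new or still open speak of the compounds shown alone.

Of the compounds shown here, two in this set have been measured in a functional assay on CHO-K1 cells for antagonist activity at C-X-C chemokine receptor type 3 (Homo sapiens), read by FLIPR and calcium flux; a lower number here means a stronger inhibitor, a higher number a weaker inhibitor. Compound 1 `CC1CN(S(=O)(=O)C[C@]23CC[C@H](CC2=O)C3(C)C)CCN1c1ccc(C(F)(F)F)cn1` gives 316 nM. Compound 2 `C[C@@H]1CN(c2ccc(C(F)(F)F)cn2)[C@@H](C)CN1S(=O)(=O)C[C@]12CC[C@H](CC1=O)C2(C)C`, which carries two methyl groups on its central ring, gives 6310 nM, the highest of the two numbers and a step beyond the usual scatter from compound 1. Compound 3 `C[C@H]1CN(S(=O)(=O)C[C@]23CC[C@H](CC2=O)C3(C)C)CCN1c1ccc(C(F)(F)F)cn1` has not yet been measured; it differs from compound 2 by hydrogen in place of methyl on a saturated ring carbon. Among the measured compounds shown here, no measured pair in this set shows exactly this change, so its size can only be expected, not read off. Compound 3 is expected to come out considerably lower than compound 2, because the closely related compound 1 gives 316 nM, and the expected step is a 16-fold lower number from compound 2 to compound 3 (1.20 log units; beyond the scatter). For compound 3 the estimate in this assay is 400 nM, within a range from 100 nM to 2000 nM.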

Compound 3, half-maximal inhibitory concentration: 158 nM
For compound 3 the middle estimate is 2.5-fold (0.40 log units) above the measured one; the range from low to high includes it.
By their numbers in this assay, from the lowest: compounds 3 and 1 (each within the scatter of the next); then compound 2.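

Replacing methyl with hydrogen on this saturated ring carbon gives a 40-fold lower number from compound 2 to compound 3 (1.60 log units; beyond the scatter) in this assay, so this single methyl, with no hydrogen-bond donors or acceptors, accounts on its own for a large share of the weak inhibition of compound 2. The step to the compound with a drawn configuration at the remaining methyl-bearing carbon is a 2.0-fold lower number from compound 1 to compound 3 (0.30 log units; within the scatter), so drawing that centre as S adds nothing that can be told from the scatter. The two compounds are set apart only by this: the fact that one of compounds 1 and 3 is drawn with a defined configuration and the other without, at the place where they differ

On these data alone, how the opposite configuration at that carbon would compare stays open. As far as these compounds go, it is also open whether an ethyl or a hydroxymethyl group on the saturated ring carbon would behave like methyl or like hydrogen.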